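Adding a Benzyl Group to the Amino Nitrogen of Compound 1

The source may report more compounds than this note shows. Statements on the series, on what has been measured and on what is new or still open speak of the compounds shown alone.

Compound 1, with the structure `Nc1nc(N2CCN(C3CCCC3)CC2)c2ncn(CCCN3CCCC3)c2n1`, was tested in an assay on HEK293 cells for antagonist activity at Toll-like receptor 9 (Homo sapiens), read by spectrophotometry (a lower number here means a stronger inhibitor, a higher number a weaker inhibitor), where compound 1 gives 120 nM. Among the three compounds measured so far, compound 1 holds the second highest number. Its nearest neighbour is compound 3, `CCN1CCN(c2nc(NCc3ccc(F)cc3)nc3c2ncn3CCCN2CCCC2)CC1`, which in this assay gives 40 nM, a lower number and a gap beyond the usual scatter. Furthest from it is compound 2, `CCN1CCN(CCCn2cnc3c(N4CCN(CC)CC4)ncnc32)CC1`, which in this assay gives 1190 nM, a higher number, again beyond the scatter. No two of these compounds differ in only one place, so no single structural change can be tied to any of these gaps.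

Compound 4, `CN(C)Cc1ccc(CNc2nc(N3CCN(C4CCCC4)CC3)c3ncn(CCCN4CCCC4)c3n2)cc1`, has not yet been measured. It is compound 1 with one change: 4-((dimethylamino)methyl)benzyl in place of hydrogen on a nitrogen on an aromatic ring. Among the compounds with values here, with no measured pair sharing this change, the direction of the step can only be guessed from the numbers available, and the only compound with a lower number than compound 1 is compound 3. The step from compound 1 to compound 4 is expected to be a 2.4-fold lower number from compound 1 to compound 4 (0.38 log units; beyond the scatter), a moderate move towards a lower number, just beyond the scatter. Compound 4 is therefore estimated to give 50 nM, with a likely range from 15 nM to 200 nM.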

Compound 4, half-maximal inhibitory concentration: 7 nM
Estimate against measurement, compound 4: 7.1-fold (0.85 log units) above; measured number outside the range, below it.
By their numbers in this assay, from the lowest: compound 4; then compound 3; then compound 1; then compound 2.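

In this assay, placing 4-((dimethylamino)methyl)benzyl on the amino nitrogen of the shared core gives a 17-fold lower number from compound 1 to compound 4 (1.23 log units; beyond the scatter), a large step and the only one among these compounds that can be tied to a single change. It shows that this nitrogen, which carries only hydrogen in compound 1, can take a group of 11 heavy atoms, including a six-membered aromatic ring, and that the inhibitor becomes stronger rather than weaker. No measurement at hand says why the number falls.

The step cannot yet be divided between the benzyl part of the new group and its dimethylamino part: that would take a plain benzyl on the same nitrogen, or a morpholine or a carboxylic acid in place of the dimethylamino group. Going by these compounds, compound 3 also carries a benzyl-type group on its amino nitrogen, but it differs from compound 1 in more than one place, so it cannot settle the question, and how a longer chain between the aromatic ring and the amine would behave remains open as well.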